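The source may report more compounds than this note shows. Statements on the series, on what has been measured and on what is new or still open speak of the compounds shown alone.

Of the compounds shown here, three have been measured in a functional assay on HL-60 cells (Homo sapiens) for inhibition, read by MTT assay, with a stated time of 72 h; on this read-out higher numbers stand for weaker inhibition and lower numbers for stronger inhibition. Compound 1 `CCc1nc(-c2ccccc2F)c(C(=O)N2CCN(c3cccc(Cl)c3)CC2)o1` gives 139 nM, compound 2 `CCc1nc(-c2ccc(C(C)C)cc2)c(C(=O)N2CCN(c3cccc(OC)c3)CC2)o1` gives 887 nM, and compound 3 `CCc1nc(-c2ccc(F)cc2)c(C(=O)N2CCN(c3cccc(OC)c3)CC2)o1` gives 411 nM. Compound 3 therefore stands second highest of the three numbers: the nearest is compound 2, and the furthest is compound 1, whose number is lower. Going by the values given here, the one single-point step so far, a 2.2-fold lower number from compound 2 to compound 3 (0.33 log units; beyond the scatter), concerns a substituent swap on the pendant aromatic ring and is modest.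

Compound 4 `CCc1nc(-c2ccccc2F)c(C(=O)N2CCN(c3cccc(OC)c3)CC2)o1` is reached from compound 3 by a change of 2-fluorophenyl in place of 4-fluorophenyl on an aromatic carbon. Among the compounds with values here, no measured step covers moving the fluorine between these two positions, so the expectation rests on weaker ground. The 2-fluorophenyl entering in compound 4 is also carried by compound 1, which gives 139 nM. This hints that the ring arrangement entering in compound 4 is compatible with a lower number. A small lowering is therefore expected, a 1.6-fold lower number from compound 3 to compound 4 (0.22 log units; within the scatter), close to the scatter. Compound 4 is estimated at 250 nM, with a range from 100 nM to 600 nM.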

Compound 4, half-maximal inhibitory concentration: 607 nM
Compound 4: the middle estimate sits 2.4-fold (0.39 log units) below what was measured, outside the stated range (above it).
By their numbers in this assay, from the lowest: compound 1; then compounds 3, 4 and 2 (each within the scatter of the next, the first and the last beyond it).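

In this assay, moving the fluorine on the aromatic carbon next to the ring nitrogen stays within the scatter, a 1.5-fold higher number from compound 3 to compound 4 (0.17 log units; within the scatter), so 2-fluorophenyl and 4-fluorophenyl cannot be told apart here. Replacing 4-isopropylphenyl with 2-fluorophenyl also stays within the scatter, a 1.5-fold lower number from compound 2 to compound 4 (0.16 log units; within the scatter), even though a 2.2-fold lower number from compound 2 to compound 3 (0.33 log units; beyond the scatter) lies just beyond it, so with methoxy on the far aromatic ring this position has so far shown only a modest spread. The clearest step now lies at the other place, methoxy in place of chloro, a 4.4-fold higher number from compound 1 to compound 4 (0.64 log units; beyond the scatter), which is beyond the scatter.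

Still open, as far as these compounds go, is whether an amine or a carboxylic acid on the phenyl ring at this position would move the number further, and whether chloro gives the same step when paired with 4-fluorophenyl. No measurement shown here accounts for any of these steps.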